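Hydroxy Added to the Benzyl Ring of a Coumarin Amide

A few compounds are considered here, and "the series" means these few. Any claim that something is new, unique, unknown or untested is made for them only; others in the source may bear on it.

Measured compounds:
Compound 1 `COc1cccc(Oc2ccc3cc(NC(=O)c4ccc(O)c(CC=C(C)C)c4)c(=O)oc3c2C)c1`: 33100 nM
Compound 2 `COc1ccc(Cc2ccc3cc(NC(=O)c4ccc(O)c(CC=C(C)C)c4)c(=O)oc3c2C)cc1`: 11100 nM
Compound 3 `COc1cccc(Cc2ccc3cc(NC(=O)c4ccc(O)c(CC=C(C)C)c4)c(=O)oc3c2C)c1`: 14800 nM

In a functional assay on SK-BR-3 cells (Homo sapiens) for antiproliferative activity (a lower number here means a stronger inhibitor, a higher number a weaker inhibitor), compound 3 gives 14800 nM, the second highest of the three numbers; compound 2 lies within the scatter of it, while the step of a 2.2-fold lower number from compound 1 to compound 3 (0.35 log units; beyond the scatter) lies beyond. Compound 4 `COc1cc(Cc2ccc3cc(NC(=O)c4ccc(O)c(CC=C(C)C)c4)c(=O)oc3c2C)ccc1O` carries hydroxy in place of hydrogen on an aromatic carbon. Among the measured compounds shown here, no measured step adds a hydroxy group. The known steps concern the linker, a 3.0-fold lower number from compound 1 to compound 2 (0.47 log units; beyond the scatter) and a 2.2-fold lower number from compound 1 to compound 3 (0.35 log units; beyond the scatter), and the methoxy position, a 1.3-fold higher number from compound 2 to compound 3 (0.12 log units; within the scatter), the last within the scatter. Nothing in them points in a direction for the new change, so no step beyond the scatter is expected in this assay. The expected step is a 1.0-fold higher number from compound 3 to compound 4 (0.01 log units; within the scatter). Compound 4 is estimated at 15000 nM, ranging from 6000 nM to 40000 nM.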

Compound 4, half-maximal inhibitory concentration: 10700 nM
Estimate against measurement, compound 4: 1.4-fold (0.15 log units) above; low and high end bracket the measured number.
By their numbers in this assay, from the lowest: compounds 4, 2 and 3 (each within the scatter of the next); then compound 1.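

In this assay the 4-hydroxy-3-methoxybenzyl group, with its hydroxy ortho to the methoxy group, reads the same as the 3-methoxybenzyl group (a 1.4-fold lower number from compound 3 to compound 4 (0.14 log units; within the scatter)) and the 4-methoxybenzyl group (a 1.0-fold lower number from compound 2 to compound 4 (0.02 log units; within the scatter)). This aromatic carbon therefore takes a hydroxy group without a change that can be read. The benzyl linker's separation from the 3-methoxyphenoxy compound survives the addition (a 3.1-fold lower number from compound 1 to compound 4 (0.49 log units; beyond the scatter)).

No available evidence bears on this result. On these data alone, whether an amine or a carboxylic acid on this carbon would move the number remains open.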